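Benzyl aryl substitution on the shared core: compound 3

A few compounds are considered here, and "the series" means these few. Any claim that something is new, unique, unknown or untested is made for them only; others in the source may bear on it.

In an assay on Sf21 cells for inhibition of high affinity nerve growth factor receptor (Homo sapiens), read by HTRF, with a stated time of 30 min, in the presence of a further agent that is not named here (on this read-out lower numbers stand for stronger inhibition and higher numbers for weaker inhibition), compound 1 `CC1(C)c2[nH]nc(NC(=O)c3ccccc3)c2CN1Cc1cccc(I)c1` gives 1360 nM. Within the data shown here, compound 2 `CC1(C)c2[nH]nc(NC(=O)c3ccccc3)c2CN1Cc1ccc(F)cc1F` gives 2320 nM in this assay, so compound 2 and compound 1 lie within the scatter of each other; the only step among the measured pair is a 1.7-fold higher number from compound 1 to compound 2 (0.23 log units; within the scatter). Compound 3 `Cc1ccc(CN2Cc3c(NC(=O)c4ccccc4)n[nH]c3C2(C)C)cc1F` is not yet measured. Its difference from compound 2 is 3-fluoro-4-methylphenyl in place of 2,4-difluorophenyl on a saturated chain carbon bound to an amine nitrogen in a ring, again a change of the aryl group on the benzyl arm. Among the measured compounds shown here, the one step that bears on it, a 1.7-fold higher number from compound 1 to compound 2 (0.23 log units; within the scatter), was within the scatter, so the two aryl groups examined so far gave no separation in this assay. With nothing more to go on, the step from compound 2 to compound 3 is expected to be a 1.2-fold lower number from compound 2 to compound 3 (0.06 log units; within the scatter), with no direction beyond the scatter. Compound 3 is estimated at 2000 nM in this assay, within a range of 800 nM to 5000 nM.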

Compound 3, half-maximal inhibitory concentration: 940 nM
Compound 3: middle estimate off by 2.1-fold (0.33 log units), on the high side; the measured number falls inside the stated range.
By their numbers in this assay, from the lowest: compounds 3, 1 and 2 (each within the scatter of the next, the first and the last beyond it).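

The benzyl arm gives its first separation in this assay (a 2.5-fold lower number from compound 2 to compound 3 (0.39 log units; beyond the scatter)), a modest step for 3-fluoro-4-methylphenyl in place of 2,4-difluorophenyl on the same saturated chain carbon. Among these compounds, the same group set against 3-iodophenyl gives no such separation (a 1.4-fold lower number from compound 1 to compound 3 (0.16 log units; within the scatter)), so this aryl position is not silent, but only the pair of compound 2 and compound 3 stands apart. Nothing measured here accounts for that gap.

The 2,4-difluorophenyl to 3-fluoro-4-methylphenyl change alters more than one substituent at once, so the step cannot be assigned to the methyl group or to the placing of the fluorines. Going by these compounds, how an aryl group bearing an amine or a carboxylic acid, or a longer chain in place of the benzyl carbon, would read in this assay remains open.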